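The compounds below may be only part of what the source reports. "The series", "measured", "known", "first", "only" and "open" are said of these compounds alone.

Measured so far:
- compound 1 `CC(C)n1cnc2c(Nc3ccccc3)nc(NCOCc3ccc(C(=O)Nc4ccccc4N)cc3)nc21`: 6.85%
- compound 2 `CCC(C)n1cnc2c(NCc3ccc(C(=O)Nc4ccccc4N)cc3)nc(Cl)nc21`: 74.6%
- compound 3 `CC1CCN(c2nc(Cl)nc3c2ncn3Cc2ccc(/C=C/C(=O)Nc3ccccc3N)cc2)CC1`: 4.24%

In a functional assay on HCT-116 cells (Homo sapiens) for antiproliferative activity, read by CCK-8 assay, with a stated time of 72 h, tested at 2 uM (a higher number here means a stronger effect of the compound at the concentration tested, a lower number a weaker effect), compound 2 gives 74.6%, the highest of the three numbers. The nearest is compound 1 with 6.85%, which lies beyond the scatter below compound 2; the furthest is compound 3 with 4.24%, also beyond the scatter below it. Compound 2 is therefore the most active of the three. Among the compounds with values here, no pair of measured compounds differs in only one place, so no single-change step in this assay is known from the measured set.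

Compound 4 `Nc1ccccc1NC(=O)c1ccc(CNc2nc(Cl)nc3c2ncn3C2CCCC2)cc1` has not yet been measured. It differs from compound 2 in one place:

cyclopentyl in place of sec-butyl on an aromatic nitrogen

Both groups are small hydrocarbons without donors, acceptors or charge, and the change is small in count. Within the data shown here, with no measured step of this kind to rest on, the expectation is a step of a number 6.6 percentage points lower from compound 2 to compound 4 (within the scatter) from compound 2 to compound 4 that stays within the usual scatter, with a slight lean downward. Compound 4 is accordingly estimated at 68% in this assay, with a range from 42% to 88%.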

Compound 4, a percentage reported as inhibition, at one concentration (the size of the read-out at that concentration, not a potency): 75.6%
Compound 4: middle estimate off by 7.6 percentage points, on the low side, and the stated range covers the measured number.
By their numbers in this assay, from the lowest: compounds 3 and 1 (each within the scatter of the next); then compounds 2 and 4 (each within the scatter of the next).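

In this assay, within the data shown here, cyclopentyl in place of sec-butyl on an aromatic nitrogen gives the first single-change reading, and the step is a number 1 percentage points higher from compound 2 to compound 4 (within the scatter), so this change leaves the read-out unresolved from that of the starting compound. The position therefore accepts a five-membered carbon ring in place of the open sec-butyl group, with one more carbon and no donor, acceptor or charge on either side, without a step beyond the scatter. Nothing available explains why the two groups read alike, and no measurement bearing on a cause can be cited.

From the compounds shown here alone, whether the same holds for a larger ring such as cyclohexyl, a flat ring such as phenyl, a longer chain such as n-hexyl, or a group carrying an amine at this nitrogen stays open, as does whether it holds outside the shared core of compound 2 and compound 4. The read-out is taken at one concentration. This single pair of numbers gives the size of the effect of compound 2 and compound 4 at that concentration and does not show how their effects compare at any other concentration.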